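Dropping the Acetyl from Compound 1

The source may hold more compounds than are shown below. What is called first, only, known or untested is meant among the compounds shown, and "the series" means these compounds.

Compound 1 `CC(=O)c1cc2ccc(C(c3ccc(F)cc3)N3CCCCC3)c(O)c2o1` is measured in an assay for inhibition of protein disulfide-isomerase (Homo sapiens), with a stated time of 1 h (on this read-out lower numbers stand for stronger inhibition and higher numbers for weaker inhibition), where compound 1 gives 1230 nM. Among the two numbers shown, that of compound 1 is the highest; its nearest neighbour is compound 2 `Cc1ccnc(NC(c2cccc(F)c2)c2ccc3cccnc3c2O)c1`, which in this assay gives 350 nM, a gap beyond the usual scatter. Compound 3 `Oc1ccc2cnccc2c1C(c1ccc(F)cc1)N1CCCCC1` reaches only the limit of this assay, shown as > 100000 nM (the limit of > 100000 nM in this assay, at which 1 of the 3 values shown sits). Compound 4 `Oc1c(C(c2ccc(F)cc2)N2CCCCC2)ccc2ccoc12` differs from compound 1 by a single change: hydrogen in place of acetyl on an aromatic carbon. For the measured compounds named here, no measured pair shows this same step, so its size is open, and the estimate here rests on compound 1 alone. The expected step is a 3.3-fold higher number from compound 1 to compound 4 (0.51 log units; beyond the scatter), toward a higher number. Compound 4 is estimated at 4000 nM, with a range from 1000 nM to 20000 nM.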

Compound 4, half-maximal inhibitory concentration: 560 nM
Compound 4: the middle estimate sits 7.1-fold (0.85 log units) above what was measured; the whole stated range lies above it.
By their numbers in this assay, from the lowest: compounds 2 and 4 (each within the scatter of the next); then compound 1. At a limit, above all of these: compound 3.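

In this assay hydrogen in place of acetyl on this aromatic carbon, next to the ring oxygen, gives a 2.2-fold lower number from compound 1 to compound 4 (0.34 log units; beyond the scatter) and shows that the acetyl is not needed for inhibition in this series. At this position, its removal brings a modest gain rather than a loss. Nothing measured here explains why the number moves. On these data alone, how this carbon responds to other groups stays open, since an amine, a carboxylic acid or a longer chain such as propyl could move the number either way.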